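A few compounds are considered here, and "the series" means these few. Any claim that something is new, unique, unknown or untested is made for them only; others in the source may bear on it.

Compound 1, `COc1cc(CCc2ccccc2O)cc(OC)c1`, was examined in an ADME assay on KB cells (Homo sapiens) for cytotoxicity, read by colorimetric assay; on this read-out higher numbers stand for weaker inhibition and lower numbers for stronger inhibition. In this assay compound 1 gives > 77500 nM, which is a limit of the assay rather than a number. Compound 2, `COc1cc(CCc2ccccc2O)cc(O)c1C`, belongs to the same set. In this assay compound 2 likewise gives > 77500 nM, again a limit of the assay. Compound 1 therefore stands at the limit of > 77500 nM in this assay, at which 2 of the 2 values shown sit. Compound 3, `COc1cc(CCc2ccccc2O)c(O)c(OC)c1`, has not yet been measured. It differs from compound 1 by hydroxy in place of hydrogen on an aromatic carbon, the hydroxy group entering on an aromatic carbon of a six-membered aromatic ring of carbon only, ortho to a methoxy group and para to a methoxy group. Among the measured compounds shown here, no step between measured compounds is available, so the size of this step in this assay cannot be read from the data; with both measured compounds sitting at the limit, no step beyond the scatter is expected in either direction. Compound 3 is expected to give about 80000 nM, within a range from 40000 nM to 160000 nM, most likely reported again only as a limit. The expected step is a step that the limit leaves unreadable from compound 1 to compound 3.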

Compound 3, half-maximal inhibitory concentration: > 72900 nM
Compound 3 ended at the assay's limit; the forecaster's own chance of this, stated with the estimate: 80%; the middle value is on the limit's open side.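

In this assay, among the compounds shown here, compound 1 and compound 3 both stand only at limits of the assay, and no step between them can be read. The compounds shown leave open whether hydroxy in place of hydrogen changes this read-out at all: compound 1, compound 2 and compound 3 give no number.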